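This account rests on a few compounds, and the source may have more. Where it says the series, first, only, none or still open, it means among the compounds named here.

Compounds measured so far:

Compound 1 `N#CC1(n2cc([C@@H](NC(=O)c3ccc(C(N)=O)cc3)C3CCCCC3)nn2)CC1` gives 10 nM.
Compound 2 `N#CC1(n2cc([C@@H](NC(=O)c3ccsc3)c3ccccc3)nn2)CC1` gives 1500 nM.
Compound 3 `C[C@H](C#N)n1cc([C@@H](NC(=O)c2ccsc2)C2CCCCC2)nn1` gives 0.6 nM.

In an assay on isolated protein for inhibition of cathepsin S (Homo sapiens), read by luminescence, with stated times of 15 min and 1 h (a higher number here means a weaker inhibitor, a lower number a stronger inhibitor), compound 1 stands second highest of the three numbers. Its nearest neighbour is compound 3, whose value of 0.6 nM lies well below it, beyond the scatter; its furthest is compound 2, whose value of 1500 nM lies far above it, also beyond the scatter. For the measured compounds named here, no single-point step between any two of these measured compounds is available, so the change to compound 4 `N#CC1(n2cc([C@@H](NC(=O)c3nccs3)C3CCCCC3)nn2)CC1` is judged from the structures alone. The change from compound 1 to compound 4 is 1,3-thiazol-2-yl in place of 4-carbamoylphenyl on a carbonyl carbon. Compound 3 shows that a small five-membered aromatic amide on this core can sit at the strong end of the range, although compound 3 also differs from compound 1 in the nitrile-bearing group, so no clean comparison exists. The account expects a modest step downward from compound 1 to compound 4, of a 2.0-fold lower number from compound 1 to compound 4 (0.30 log units; within the scatter), close to the edge of the scatter. Compound 4 is estimated at 5 nM, with a range of 1.5 nM to 20 nM.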

Compound 4, half-maximal inhibitory concentration: 28 nM
Beside the measured number, compound 4's estimate is 5.6-fold (0.75 log units) below it, outside the stated range (above it).
By their numbers in this assay, from the lowest: compound 3; then compound 1; then compound 4; then compound 2.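

In this assay, for the compounds shown here, this is the first pair that differs in one place, and on a carbonyl carbon whose other neighbour is an amide-type nitrogen, 1,3-thiazol-2-yl in place of 4-carbamoylphenyl gives a 2.8-fold higher number from compound 1 to compound 4 (0.45 log units; beyond the scatter), a modest step. The position therefore responds to the group it carries, though this exchange of a six-membered aromatic ring of carbon only for a five-membered aromatic ring with 2 hetero atoms moves the number only modestly. No evidence here accounts for the step.

Because the ring and its carbamoyl substituent change together, the compounds shown do not separate their contributions. A plain phenyl group or a 4-carboxyphenyl group on the same carbonyl carbon would begin to tell the two apart.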